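Exchanging propyl for cyano on the amide-bearing ring

The source may report more compounds than this note shows. Statements on the series, on what has been measured and on what is new or still open speak of the compounds shown alone.

The series shares one core, carrying two carboxylic acids on an anilide, and varies the group on the benzoyl ring. Compound 1 `CCCc1ccc(C(=O)Nc2cc(C(=O)O)cc(C(=O)O)c2)cc1` is measured in a functional assay on the whole organism (stomach) with Rattus norvegicus as the target (a lower number here means that less compound is needed, a higher number that more compound is needed for the effect), and gives 94.2 mg/kg. Compound 2 `COc1ccc(C(=O)Nc2cc(C(=O)O)cc(C(=O)O)c2)cc1OC` in this assay gives 116 mg/kg, and compound 3 `N#Cc1cccc(C(=O)Nc2cc(C(=O)O)cc(C(=O)O)c2)c1` in this assay gives 140 mg/kg. Compound 1 thus shows the lowest of the three numbers, but both compound 2 and compound 3 lie within the scatter of it, so no order among the three can be claimed.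

Compound 4 `N#Cc1ccc(C(=O)Nc2cc(C(=O)O)cc(C(=O)O)c2)cc1` has not yet been measured. It differs from compound 1 in one place: cyano in place of propyl on an aromatic carbon. Compound 3 also carries a cyano group on its benzoyl ring and gives 140 mg/kg, a number within the scatter of compound 1. Hence the change from compound 1 to compound 4 is expected to produce at most a small step, a 1.3-fold higher number from compound 1 to compound 4 (0.12 log units; within the scatter), not clearly beyond the scatter, if anything toward a higher number. For compound 4 in this assay the estimate is 125 mg/kg, with a range from 70 mg/kg to 230 mg/kg.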

Compound 4, dose for 50% inhibition: 32.1 mg/kg
Estimate against measurement, compound 4: 3.9-fold (0.59 log units) above; measured number below the stated range.
By their numbers in this assay, from the lowest: compound 4; then compounds 1, 2 and 3 (each within the scatter of the next).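

In this assay, cyano in place of propyl on an aromatic carbon, para to a large group, gives a 2.9-fold lower number from compound 1 to compound 4 (0.47 log units; beyond the scatter). Among the compounds shown here, this is the first difference that lies beyond the scatter, whereas the three earlier numbers could not be ordered, and it shows that the number responds to the group at this position. Nothing shown here explains why the step occurs.

A single pair cannot separate the arrival of the cyano group from the departure of the propyl group, and compound 3, which also carries a cyano group, gives 140 mg/kg, so the cyano group alone does not fix the number. The compounds shown leave open how an amine, a carboxylic acid or a longer chain at this position would compare with cyano.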